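The source may report more compounds than this note shows. Statements on the series, on what has been measured and on what is new or still open speak of the compounds shown alone.

Working notes on the series. Three compounds have numbers in an ADME assay on microsomes from liver (Homo sapiens) for metabolic stability, tested at 2.5 uM; on this read-out higher numbers stand for fast clearance and lower numbers for slow clearance. Compound 1 `N#Cc1cccc(S(=O)(=O)c2cnc3cc(F)ccc3c2-c2cccc(Cl)c2)c1` gives 0.99 mL/min. Compound 2 `COc1ccc(S(=O)(=O)c2cnc3cc(F)ccc3c2-c2cccc(F)c2)cc1` gives 2.94 mL/min. Compound 3 `Cc1ccc(S(=O)(=O)c2cnc3cc(F)ccc3c2-c2cccc(F)c2)cc1F` gives 0.41 mL/min and stands lowest of the three, with compound 1 nearest and compound 2 furthest. Within the data shown here, the one single-site step among them is a 7.2-fold lower number from compound 2 to compound 3 (0.86 log units; beyond the scatter).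

Compound 4 `N#Cc1cccc(S(=O)(=O)c2cnc3cc(F)ccc3c2-c2cccc(F)c2)c1` has not been measured in this assay. It differs from compound 3 as follows: 3-cyanophenyl in place of 3-fluoro-4-methylphenyl on a sulfonyl sulfur.

Among the measured compounds shown here, no measured step exchanges these two groups on the sulfonyl sulfur. Compound 1 carries the same 3-cyanophenyl group as compound 4 and differs from it elsewhere; no step for that pair is shown, so only the values speak: compound 1 gives 0.99 mL/min, whereas compound 3 gives 0.41 mL/min. Given that compound 1 gives 0.99 mL/min, compound 4 is expected to come out nearer that number than compound 3, so a step of a 2.2-fold higher number from compound 3 to compound 4 (0.34 log units; beyond the scatter) is estimated, upward and beyond the scatter, though with wide uncertainty. For compound 4 the estimate is 0.9 mL/min, ranging from 0.4 mL/min to 2 mL/min.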

Compound 4, intrinsic clearance in a liver preparation (reported as CLH), per the amount of preparation that the assay uses: 0.78 mL/min
The estimate for compound 4 lay 1.2-fold (0.06 log units) above the measured number, within the range that was stated.
By their numbers in this assay, from the lowest: compounds 3, 4 and 1 (each within the scatter of the next, the first and the last beyond it); then compound 2.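

In this assay the 3-cyanophenyl and 3-fluoro-4-methylphenyl groups on the sulfonyl sulfur cannot be told apart, as a 1.9-fold higher number from compound 3 to compound 4 (0.28 log units; within the scatter) stands within the scatter. Among the three groups compared at this place, only 4-methoxyphenyl stands apart, since a 3.8-fold lower number from compound 2 to compound 4 (0.58 log units; beyond the scatter) and the earlier 7.2-fold lower number from compound 2 to compound 3 (0.86 log units; beyond the scatter) both lie beyond the scatter. The series now also holds a single-site step on the other aryl group, fluoro in place of chloro on an aromatic carbon, and a 1.3-fold lower number from compound 1 to compound 4 (0.10 log units; within the scatter) also stays within the scatter.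

Open, as far as these compounds go, is where an amine, a carboxylic acid or a longer chain on the sulfonyl sulfur would fall, and whether the fluoro and chloro exchange stays this small with other groups there. No measurement shown gives a reason for any of these steps.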